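This account rests on a few compounds, and the source may have more. Where it says the series, first, only, none or still open, it means among the compounds named here.

In a functional assay on MCF7 cells (Homo sapiens) for inhibition, read by MTT assay, with a stated time of 72 h (on this read-out lower numbers stand for stronger inhibition and higher numbers for weaker inhibition), three compounds built on a shared core have been measured. Compound 1 (`COC(=O)CCCCCCC(=O)Nc1cccc(OS(=O)(=O)C2CC3OC2C(c2ccc(O)cc2)=C3c2ccc(O)cc2)c1`) gives 19100 nM, compound 2 (`COc1ccccc1OS(=O)(=O)C1CC2OC1C(c1ccc(NC(=O)CCCCCCC(=O)NO)cc1)=C2c1ccc(O)cc1`) gives 25800 nM, and compound 3 (`Cc1ccccc1OS(=O)(=O)C1CC2OC1C(c1ccc(NC(=O)CCCCCCC(=O)O)cc1)=C2c1ccc(O)cc1`) gives 7900 nM. Compound 2 stands level with compound 1 within the usual scatter, while compound 3 has a lower number, beyond that scatter.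

Compound 4 (`O=C(CCCCCCC(=O)Nc1ccc(C2=C(c3ccc(O)cc3)C3CC(S(=O)(=O)Oc4ccc(Br)cc4)C2O3)cc1)NO`) is compound 2 with a single change: 4-bromophenyl in place of 2-methoxyphenyl on an oxygen whose other neighbour is the sulfonyl sulfur (4-bromophenyl in place of 2-methoxyphenyl on an oxygen). Going by the values given here, no measured pair isolates this swap, so the data give no direct guide to its effect. The only support is the spread of the measured set, which reaches down to compound 3 at 7900 nM. A modest shift toward a lower number is therefore expected, one that stays within the scatter, and the estimated step is a 1.6-fold lower number from compound 2 to compound 4 (0.21 log units; within the scatter). For compound 4 the estimated value is 16000 nM, with an expected range of 6000 nM to 40000 nM.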

Compound 4, half-maximal inhibitory concentration: 17100 nM
For compound 4 the middle estimate is 1.1-fold (0.03 log units) below the measured one; the measured number falls inside the stated range.
By their numbers in this assay, from the lowest: compound 3; then compounds 4, 1 and 2 (each within the scatter of the next).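

In this assay, going by these compounds alone, swapping 4-bromophenyl for 2-methoxyphenyl on an oxygen whose other neighbour is the sulfonyl sulfur gives a 1.5-fold lower number from compound 2 to compound 4 (0.18 log units; within the scatter), the first direct reading of a change at this position. In this one pair, the position takes a different substituted phenyl ring, with the substituent also changed in kind and placement, without a shift that stands out from the usual variation between repeat measurements. Nothing available explains why these two groups read alike.

From the compounds shown here alone, a single pair cannot show how far this tolerance extends, so it remains open how a plain phenyl, a 3-bromophenyl or a pyridine ring would read here. Going by these compounds, it is also open whether an amine on the ring would leave the number just as little changed.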